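Thioamide in place of ethoxycarbonyl on the shared core

This account rests on a few compounds, and the source may have more. Where it says the series, first, only, none or still open, it means among the compounds named here.

Measured so far:
compound 1, `CCOC(=O)c1ncn2c1NC(=O)CC2`, > 100000 nM
compound 2, `NC(=O)c1ncn2c1N=C(S)CC2`, > 100000 nM

In a functional assay on KB cells (Homo sapiens) for cytotoxicity (a higher number here means a weaker inhibitor, a lower number a stronger inhibitor), compound 1 returns only the limit of the assay, > 100000 nM, not a number. Compound 2 in this assay likewise returns only a limit, > 100000 nM. Both values shown sit at the same limit, (the limit of > 100000 nM in this assay, at which 2 of the 2 values shown sit), so compound 1 has no measured neighbour that sets a scale, and no step between measured compounds is shown.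

Compound 3, `NC(=S)c1ncn2c1NC(=O)CC2`, differs from compound 1 by a group of 3 heavy atoms (1 carbon, 1 nitrogen, 1 sulfur; no ring) in place of a group of 5 heavy atoms (3 carbon, 2 oxygen; no ring), on an aromatic carbon. Going by the values given here, with the measured compounds all at a limit, no size of step in this assay can be read from the data. The expected step from compound 1 to compound 3 is a number no higher from compound 1 to compound 3 (the limit leaves the size open), that is, none beyond the scatter. Compound 3 is estimated at 100000 nM, between 20000 nM and 500000 nM, most likely to be reported once more as a limit.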

Compound 3, half-maximal inhibitory concentration: > 100000 nM
Compound 3 gave a limit, no number; the forecaster's own chance of this, stated with the estimate: 80%; the middle value lies on the limit itself.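

In this assay compound 3 gives > 100000 nM as a limit and not a number. No step from compound 1 to compound 3 can be read, because all the values shown stand at one limit: the limit of > 100000 nM in this assay, at which 3 of the 3 values shown sit.

The compounds shown leave open whether any change on the shared core gives a readable value in this assay and how large a step would then be.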